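The source may report more compounds than this note shows. Statements on the series, on what has been measured and on what is new or still open speak of the compounds shown alone.

Measured in an ADME assay on the whole organism (Mus musculus, strain CD1) for metabolic stability, at a dose of 2 mg/kg by the intravenous route; a lower number here means that the compound disappears faster, a higher number that the compound lasts longer:
- compound 1 `CN1CCC(Oc2ccc(N3C(=S)N(c4cnc(C#N)c(C(F)(F)F)c4)C(=O)C34CCC4)cc2)CC1`: 46.4 h
- compound 2 `CN1CCC(Oc2ccc(N3C(=S)N(c4cnc(C#N)c(C(F)(F)F)c4)C(=O)C34CCC4)cn2)CC1`: 12.5 h
- compound 3 `N#Cc1ncc(N2C(=O)C3(CCC3)N(c3ccc(CN4CCNCC4)cc3)C2=S)cc1C(F)(F)F`: 12.1 h

Compound 1 has the highest number of the three, and compounds 2 and 3 both stand lower, beyond the scatter. The next compound, compound 4 `COc1cc(N2C(=O)C3(CCC3)N(c3ccc(OC4CCN(C)CC4)cc3)C2=S)cnc1C#N`, keeps most of compound 1 and changes one group: methoxy in place of trifluoromethyl on an aromatic carbon. Methoxy takes the place of trifluoromethyl on an aromatic carbon, ortho to a cyano group.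

Among the compounds with values here, no measured step makes this exchange, so the evidence is indirect. Within the data shown here, the only step available, a 3.8-fold lower number from compound 1 to compound 3 (0.58 log units; beyond the scatter), changes a different group and can only suggest a size. With compound 1 at the top of a small set, a lower number of similarly modest size is expected in this assay, though with wide uncertainty. The expected step is a 2.9-fold lower number from compound 1 to compound 4 (0.46 log units; beyond the scatter). Compound 4 is estimated at 16 h, with an expected range from 5 h to 45 h.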

Compound 4, half-life: 7.8 h
Compound 4: the middle estimate sits 2.1-fold (0.31 log units) above what was measured; measured number inside the range.
By their numbers in this assay, from the lowest: compounds 4, 3 and 2 (each within the scatter of the next); then compound 1.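

Within the data shown here, the only earlier step changed a different group, so this is the first reading at the aromatic carbon ortho to a cyano group. In this assay, methoxy in place of trifluoromethyl gives a 5.9-fold lower number from compound 1 to compound 4 (0.77 log units; beyond the scatter), which shows that the half-life depends on what this position carries, even with the rest of compound 1 unchanged. The data offer no measurement that explains the size of this step.

On these data alone, only trifluoromethyl and methoxy appear at this position, so it remains open where a methyl group, a chlorine atom or an ethoxy group would fall relative to them. As far as these compounds go, it is also open whether the same exchange would give a step of similar size on compound 2 or compound 3, which differ from compound 1 elsewhere.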